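This account rests on a few compounds, and the source may have more. Where it says the series, first, only, none or still open, it means among the compounds named here.

Measured in a functional assay on MCF7 cells (Homo sapiens) for cytotoxicity, read by MTT assay, with a stated time of 24 h; on this read-out higher numbers stand for weaker inhibition and lower numbers for stronger inhibition:
- compound 1 `CCCCC(=O)NC(=S)Nc1nc2cc([N+](=O)[O-])ccc2s1`: > 100000 nM (a limit, not a number)
- compound 2 `O=C(NC(=S)Nc1nc2ccccc2s1)c1ccccc1`: 37300 nM
- compound 3 `Nc1ccc2sc(NC(=S)NC(=O)c3ccc([N+](=O)[O-])cc3)nc2c1`: 33200 nM

Compound 1 is known only as a limit, > 100000 nM, and its standing is this: the limit of > 100000 nM in this assay, at which 1 of the 3 values shown sits. Compound 4 `O=C(NC(=S)Nc1nc2cc([N+](=O)[O-])ccc2s1)N1CCOCC1` keeps the core of compound 1 and has morpholin-4-yl in place of butyl on a carbonyl carbon. Among the compounds with values here, no measured pair shows this change, so the only guides are compound 2 at 37300 nM and compound 3 at 33200 nM. A small expected shift towards stronger inhibition in this assay is the working assumption, and no shift beyond the scatter is equally possible. The expected step is an at least 1.4-fold lower number from compound 1 to compound 4 (0.15 log units; that floor lies within the scatter). The estimate for compound 4 is 70000 nM, with an expected range of 25000 nM to 150000 nM.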

Compound 4, half-maximal inhibitory concentration: 31000 nM
Compound 4: the middle estimate sits 2.3-fold (0.35 log units) above what was measured; the range from low to high includes it.
By their numbers in this assay, from the lowest: compounds 4, 3 and 2 (each within the scatter of the next). At a limit, above all of these: compound 1.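

In this assay, within the data shown here, morpholin-4-yl in place of butyl on a carbonyl carbon gives the first step that can be read at this position: an at least 3.2-fold lower number from compound 1 to compound 4 (0.50 log units; beyond the scatter). Compound 4 gives a number, 31000 nM, so this position can carry a change that yields a measured value. Compound 1 is known only as a limit, so the step is a floor and its full size stays unknown: the limit of > 100000 nM in this assay, at which 1 of the 4 values shown sits.

On these data alone, whether the step comes from the morpholin-4-yl ring or from the loss of butyl stays open. Piperidin-1-yl or a longer chain on the same carbonyl carbon, with the core of compound 1, would separate these readings.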